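The source may report more compounds than this note shows. Statements on the series, on what has been measured and on what is new or still open speak of the compounds shown alone.

Compound 2 `O=C(CCCCCCn1cc(Nc2ncc3ccn(Cc4ccc(Cl)cc4)c3n2)cn1)NO` gives 39% in an assay on isolated protein for inhibition of protein deacetylase HDAC6 (Homo sapiens), with a stated time of 60 min, tested at 10 nM (on this read-out higher numbers stand for more inhibition at the one concentration tested (going by the name of the read-out) and lower numbers for less inhibition), and compound 1 `O=C(CCCCCn1cc(Nc2ncc3ccn(Cc4ccc(Cl)cc4)c3n2)cn1)NO` gives 38% in this assay; the step of a number 1 percentage points higher from compound 1 to compound 2 (within the scatter) lies within the scatter, so the two numbers cannot be ordered. Compound 3 `Cc1ccc(Cn2ccc3cnc(Nc4cnn(CCCCCCC(=O)NO)c4)nc32)cc1` differs from compound 2 by methyl in place of chloro on an aromatic carbon. For the measured compounds named here, the only measured step changes the chain, not the aromatic carbon, so no measured step bears on this change. Without a comparable step, no movement beyond the scatter is expected in this assay. Compound 3 is therefore estimated at 36%, between 18% and 55%. The expected step of a number 3 percentage points lower from compound 2 to compound 3 (within the scatter) is within the scatter.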

Compound 3, a percentage reported as inhibition, at one concentration (the size of the read-out at that concentration, not a potency): 38%
Estimate against measurement, compound 3: 2 percentage points below; the measured number falls inside the stated range.
By their numbers in this assay, from the lowest: compounds 1, 3 and 2 (each within the scatter of the next).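

Going from 4-chlorobenzyl to 4-methylbenzyl in this assay gives a number 1 percentage points lower from compound 2 to compound 3 (within the scatter) and so provides the first reading at this aromatic carbon, which the chain step left untouched. At the single concentration tested, chloro and methyl cannot be told apart at this position. No measurement bearing on why accompanies this result.

On these data alone, whether an amine, a carboxylic acid or a methoxy group on this carbon would move the number beyond the scatter remains open. So does the outcome with the 4-chlorobenzyl group removed altogether.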